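Swapping methoxy for bromo on the pendant phenyl ring

A few compounds are considered here, and "the series" means these few. Any claim that something is new, unique, unknown or untested is made for them only; others in the source may bear on it.

Measured so far:
Compound 1 `CN1C(=O)C(c2ccccc2Cl)N(C)c2nc(Nc3ccc(S(N)(=O)=O)cc3)ncc21` gives 129 nM in an assay on Sf9 cells for inhibition of serine/threonine-protein kinase 4 (Homo sapiens), read by luminescence and ADP-Glo, with a stated time of 1 h, in the presence of a further agent that is not named here; a lower number here means a stronger inhibitor, a higher number a weaker inhibitor.
Compound 2 `COc1ccccc1C1C(=O)N(C)c2cnc(Nc3ccc(S(N)(=O)=O)cc3)nc2N1C` gives 251 nM in this assay.

Within the data shown here, compound 2 carries the higher of the two numbers, but its only neighbour is compound 1, and the step of a 1.9-fold higher number from compound 1 to compound 2 (0.29 log units; within the scatter) lies within the scatter, so these two numbers cannot be told apart with confidence.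

Compound 3 `CN1C(=O)C(c2ccccc2Br)N(C)c2nc(Nc3ccc(S(N)(=O)=O)cc3)ncc21` has not yet been measured. It differs from compound 2 in one place: bromo in place of methoxy on an aromatic carbon. Among the measured compounds shown here, the single measured step that bears on this change is a 1.9-fold higher number from compound 1 to compound 2 (0.29 log units; within the scatter), which exchanged chloro for methoxy on that same aromatic carbon and produced no movement beyond the scatter. Bromo, like chloro, is a halogen, and compound 1 with chloro gives 129 nM, so compound 3 is expected to land near compound 1 rather than far from either neighbour. Compound 3 is therefore estimated at about 140 nM, with a range from 60 nM to 330 nM. The expected step of a 1.8-fold lower number from compound 2 to compound 3 (0.25 log units; within the scatter) would stay within the scatter.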

Compound 3, half-maximal inhibitory concentration: 57 nM
Estimate against measurement, compound 3: 2.5-fold (0.39 log units) above; measured number below the stated range.
By their numbers in this assay, from the lowest: compound 3; then compounds 1 and 2 (each within the scatter of the next).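

In this assay the earlier pair gave no sign that this aromatic carbon, ortho to a large group, affects the number, but the exchange of methoxy for bromo now gives a 4.4-fold lower number from compound 2 to compound 3 (0.64 log units; beyond the scatter) and so shows that the choice of group here does matter, if only modestly. The two halogens are not interchangeable either: bromo in place of chloro gives a 2.3-fold lower number from compound 1 to compound 3 (0.35 log units; beyond the scatter), also modest but beyond the scatter, which puts compound 3 lowest of the three, clear of both compound 1 and compound 2. Nothing available explains why bromo gives the lower number at this carbon.

With only chloro, bromo and methoxy shown at this carbon, it remains open how a plain hydrogen, iodo, an amine or a carboxylic acid would compare. From the compounds shown here alone, it also remains open whether the gain from bromo belongs to this one place on the pendant phenyl ring or would also appear with bromo on another carbon of that ring.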